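Methyl-to-fluoro exchange on the benzyloxy ring, second instance

The compounds below may be only part of what the source reports. "The series", "measured", "known", "first", "only" and "open" are said of these compounds alone.

Compound 1 `Cc1ccc(COc2ccc(-c3cc(CN4CCN(Cc5ccc(C(F)(F)F)cc5)CC4)no3)cc2)cc1` and compound 2 `Fc1ccc(COc2ccc(-c3cc(CN4CCN(Cc5ccc(C(F)(F)F)cc5)CC4)no3)cc2)cc1` share a core and differ by one substituent: fluoro in place of methyl on an aromatic carbon. In a functional assay on Mahlavu cells (Homo sapiens) for antiproliferative activity, read by sulforhodamine B assay, with a stated time of 72 h (a higher number here means a weaker inhibitor, a lower number a stronger inhibitor), compound 1 gives 7500 nM, and in this assay compound 2 gives 3100 nM, a step of a 2.4-fold lower number from compound 1 to compound 2 (0.38 log units; beyond the scatter).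

Compound 3 `Cc1cc(-c2cc(CN3CCN(Cc4ccc(C(F)(F)F)cc4)CC3)no2)ccc1OCc1cccc(C#N)c1` sits on a different core; how its core differs from that of compound 1 is not broken down here. In this assay compound 3 gives 450 nM, the lowest number among the three measured compounds.

Compound 4 `N#Cc1cccc(COc2ccc(-c3cc(CN4CCN(Cc5ccc(C(F)(F)F)cc5)CC4)no3)cc2F)c1` is derived from compound 3 by fluoro in place of methyl on an aromatic carbon. This is the same kind of change as that from compound 1 to compound 2, but not the same: in the first case the exchanged carbon is para to a large group, whereas in compound 3 the exchanged carbon is ortho to a (3-cyanobenzyl)oxy group and meta to a large group.

Within the data shown here, only one measured pair shows this exchange, so the expectation for compound 4 rests on that single step together with the value of compound 3. Because the step of a 2.4-fold lower number from compound 1 to compound 2 (0.38 log units; beyond the scatter) was modest and the surroundings of the exchanged carbon differ, a step of a 1.5-fold lower number from compound 3 to compound 4 (0.18 log units; within the scatter) is expected from compound 3 to compound 4, with room for no change. Compound 4 is estimated to give 300 nM in this assay, expected to fall between 120 nM and 900 nM.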

Compound 4, half-maximal inhibitory concentration: 500 nM
Beside the measured number, compound 4's estimate is 1.7-fold (0.22 log units) below it, and the stated range covers the measured number.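

The new step is a 1.1-fold higher number from compound 3 to compound 4 (0.05 log units; within the scatter), so in this assay the exchange of methyl for fluoro on the core of compound 3 gives no change that can be told from the scatter. Set beside the earlier step, the exchange does not carry from one core to the other with a constant size: the same change on two cores in this assay, a 2.4-fold lower number (0.38 log units; beyond the scatter) from compound 1 to compound 2 and a 1.1-fold higher number (0.05 log units; within the scatter) from compound 3 to compound 4, 2.7-fold (0.43 log units) apart, beyond the scatter of two such steps

This comparison rests on two pairs only, and these pairs differ in more than one feature: the exchange lies on the benzyloxy ring in compound 1 and compound 2, whereas in compound 4 the fluoro stands ortho to a (3-cyanobenzyl)oxy group and meta to a large group, and the two pairs also carry different substitution on the benzyl group, so the data do not show which of these features accounts for the gap between the steps.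

Still open, from the compounds shown here alone, is whether other groups on the carbon exchanged in compound 4, such as chloro, methoxy or an amine, would move the number in this assay beyond the scatter. Also open, going by these compounds, is how the series responds when the nitrile of compound 3 gives way to a carboxylic acid or a primary amide.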